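Removing the Fluorine from a Weak Antiproliferative Scaffold

The compounds below may be only part of what the source reports. "The series", "measured", "known", "first", "only" and "open" are said of these compounds alone.

Compound 1 `COC(CN(c1ccccc1CO)S(=O)(=O)c1ccc([N+](=O)[O-])cc1)n1cc(F)c(=O)[nH]c1=O` and compound 2 `O=c1cc[nH]c(=O)n1C1CN(S(=O)(=O)c2ccccc2[N+](=O)[O-])c2ccccc2CO1` were tested in a functional assay on MCF7 cells (Homo sapiens) for antiproliferative activity; on this read-out higher numbers stand for weaker inhibition and lower numbers for stronger inhibition. In this assay compound 1 gives 55200 nM and compound 2 gives 50900 nM; the number for compound 1 is the higher of the two, yet the two lie within the usual scatter of each other. Compound 3 `COC(CN(c1ccccc1CO)S(=O)(=O)c1ccc([N+](=O)[O-])cc1)n1c(=O)cc[nH]c1=O` differs from compound 1 by a group of 8 heavy atoms (4 carbon, 2 nitrogen, 2 oxygen; one six-membered aromatic ring with 2 hetero atoms) in place of a group of 9 heavy atoms (4 carbon, 2 nitrogen, 2 oxygen, 1 fluorine; one six-membered aromatic ring with 2 hetero atoms), on a saturated chain carbon bound to an oxygen on a saturated carbon and a saturated chain carbon, the leaving group carrying fluorine and the entering group none. Among the measured compounds shown here, no measured pair shows this change, and compound 2, also without fluorine, sits close to compound 1. The step is therefore expected to stay within the scatter, a 1.0-fold lower number from compound 1 to compound 3 (0.00 log units; within the scatter). Compound 3 is estimated at 55000 nM, with a range from 20000 nM to 150000 nM.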

Compound 3, half-maximal inhibitory concentration: 55200 nM
For compound 3 the middle estimate is 1.0-fold (0.00 log units) below the measured one, and the stated range covers the measured number.
By their numbers in this assay, from the lowest: compounds 2, 1 and 3 (each within the scatter of the next).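

Among the compounds shown here, this is the first direct pair at this position. In this assay, for the compounds shown here, the fluorine on the six-membered aromatic ring with 2 hetero atoms can go with no change at the digits printed from compound 1 to compound 3 (within the scatter) and the number stays weak, so on this saturated chain carbon the fluorine carries none of the measured activity. No measurement bears on why the fluorine makes no difference here. As far as these compounds go, whether chlorine, a methyl group or an amine in the fluorine's place would move the number stays open, as does whether any change elsewhere on the core of compound 1 would.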